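Changing the amide substituent of compound 3

The compounds below may be only part of what the source reports. "The series", "measured", "known", "first", "only" and "open" are said of these compounds alone.

In a physicochemical assay for solubility, read by spectrophotometry, measured as kinetic solubility, at pH 8, tested at 500 uM (a higher number here means a more soluble compound, a lower number a less soluble compound), compound 3 (`CN1CCC(NC(=O)c2ccncc2Nc2cc(-c3ccc4ccn(C)c4c3)c3nccnc3c2)CC1=O`) gives 48 ug/mL, the highest of the three measured numbers. Compound 1 (`CNC(=O)c1ccncc1Nc1cc(-c2ccc3ccn(C)c3c2)c2nccnc2c1`) gives 4 ug/mL, and compound 2 (`Cn1cc(NC(=O)c2ccncc2Nc2cc(-c3ccc4ccn(C)c4c3)c3nccnc3c2)cn1`) gives 2 ug/mL; a 2.0-fold lower number from compound 1 to compound 2 (0.30 log units; within the scatter) remains within the scatter. Compound 4 (`CC(=O)N1CCCC(NC(=O)c2ccncc2Nc2cc(-c3ccc4ccn(C)c4c3)c3nccnc3c2)C1`) carries 1-acetylpiperidin-3-yl in place of 1-methyl-2-oxopiperidin-4-yl on an amide-type nitrogen. Going by the values given here, the two large measured steps at that place, a 12-fold higher number from compound 1 to compound 3 (1.08 log units; beyond the scatter) and a 24-fold higher number from compound 2 to compound 3 (1.38 log units; beyond the scatter), both reach the only measured compound with a six-membered non-aromatic ring in this substituent. Among the compounds with values here, compound 4 keeps such a ring, so no step beyond the scatter is expected in this assay, although no measured pair tests this exchange directly. The expected step is a 1.2-fold lower number from compound 3 to compound 4 (0.08 log units; within the scatter). Compound 4 is estimated at 40 ug/mL, with an expected range of 15 ug/mL to 100 ug/mL.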

Compound 4, solubility: 212 ug/mL
Compound 4: the middle estimate sits 5.3-fold (0.72 log units) below what was measured, and the stated range ends below it.
By their numbers in this assay, from the lowest: compounds 2 and 1 (each within the scatter of the next); then compound 3; then compound 4.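

In this assay, keeping a six-membered non-aromatic ring on the amide-type nitrogen does not fix the number: a 4.4-fold higher number from compound 3 to compound 4 (0.65 log units; beyond the scatter), although 1-acetylpiperidin-3-yl and 1-methyl-2-oxopiperidin-4-yl match in hetero atoms, double bonds, donors and acceptors. The distance from the methyl and 1-methyl-1H-pyrazol-4-yl groups also grows, with a 53-fold higher number from compound 1 to compound 4 (1.72 log units; beyond the scatter) and a 110-fold higher number from compound 2 to compound 4 (2.03 log units; beyond the scatter). No measurement here bears on why the two ring groups differ.

As far as these compounds go, whether this step follows the acetyl group or the point of attachment remains open, and 1-acetylpiperidin-4-yl would separate the two. From the compounds shown here alone, how a piperidine amine such as 1-methylpiperidin-4-yl would read at this place is also open.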